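From propyl amide back to a benzyl amide: compound 4

A few compounds are considered here, and "the series" means these few. Any claim that something is new, unique, unknown or untested is made for them only; others in the source may bear on it.

Three amides of the shared core have been measured in a functional assay on QGY7701 cells (Homo sapiens) for cytotoxicity, read by MTT assay, with a stated time of 24 h; a lower number here means a stronger inhibitor, a higher number a weaker inhibitor. Compound 1 `C=CC1=C(C(=O)NCc2ccc(C)cc2)C(c2ccc(OC)cc2)OC1` gives 43100 nM. Compound 2 `C=CC1=C(C(=O)Nc2ccc(C)cc2)C(c2ccc(OC)cc2)OC1` reaches only the limit of the assay, > 100000 nM, which is a limit and not a number. Compound 3 `C=CC1=C(C(=O)NCCC)C(c2ccc(OC)cc2)OC1` likewise sits at the limit, > 100000 nM, again a limit rather than a number. Compound 3 thus stands at the limit of > 100000 nM in this assay, at which 2 of the 3 values shown sit, and its distance from compound 2 cannot be read.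

Compound 4 `C=CC1=C(C(=O)NCc2ccccc2F)C(c2ccc(OC)cc2)OC1` differs from compound 3 by 2-fluorophenyl in place of ethyl on a saturated chain carbon bound to an amide-type nitrogen. The step that bears on this change is an at least 2.3-fold higher number from compound 1 to compound 3 (0.36 log units; beyond the scatter), which runs in the opposite direction to the change now made; compound 4 restores a benzyl-type group on the saturated chain carbon bound to the amide nitrogen, as in compound 1. The step of an at least 2.3-fold higher number from compound 1 to compound 2 (0.36 log units; beyond the scatter) concerns the phenyl amide and is not directly informative here. The step of an at least 2.0-fold lower number from compound 3 to compound 4 (0.30 log units; that floor lies within the scatter) is therefore expected to bring the number down from the limit toward the level of compound 1. Compound 4 is estimated at 50000 nM, within a range from 20000 nM to 150000 nM.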

Compound 4, half-maximal inhibitory concentration: > 100000 nM
Compound 4 gave a limit, no number; the forecaster's own chance of this, stated with the estimate: 35%; middle value at least 2.0-fold (0.30 log units) from the limit.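

A benzyl-type group on the amide-type nitrogen is therefore not enough on its own to give a measurable value: 2-fluorophenyl in place of 4-methylphenyl on the saturated chain carbon gives an at least 2.3-fold higher number from compound 1 to compound 4 (0.36 log units; beyond the scatter) in this assay. The result for compound 4 is a limit and not a number, and it adds to the values held there: the limit of > 100000 nM in this assay, at which 3 of the 4 values shown sit. Of the four amides, only compound 1 has a number, so activity at this position depends on what the aromatic ring of the benzyl-type group carries, not only on the presence of that group; the steps among compound 2, compound 3 and compound 4 cannot be read.

The compounds shown leave open how a plain benzyl group would read at this place, and so whether the methyl or the fluorine counts here. Also open, as far as these compounds go, is whether a longer chain or an amine on that chain would give a number.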